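This account rests on a few compounds, and the source may have more. Where it says the series, first, only, none or still open, it means among the compounds named here.

Measured so far in an assay on CHO cells for displacement of a labelled ligand from corticotropin-releasing factor receptor 1 (Homo sapiens); on this read-out lower numbers stand for stronger inhibition and higher numbers for weaker inhibition:
- compound 1, `COc1ccc(N2CCc3c(-n4ccc(N5CCN(C)C5=O)n4)cc(C)nc32)c(C)c1`: 794 nM
- compound 2, `COc1ccc(N2CCc3c(-n4ccc(N5CCNS5(=O)=O)n4)cc(C)nc32)c(C)c1`: 309 nM

Going by the values given here, compound 2 stands lowest of the two numbers in this assay; its nearest neighbour is compound 1, and the single measured step, a 2.6-fold lower number from compound 1 to compound 2 (0.41 log units; beyond the scatter), lies beyond the scatter, so the order of the two is real but modest.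

Compound 3, `COc1ccc(N2CCc3c(-n4ccc(N5CCOC5=O)n4)cc(C)nc32)c(C)c1`, is the next member to be measured. It differs from compound 2 in one place: a group of 6 heavy atoms (3 carbon, 1 nitrogen, 2 oxygen; one five-membered non-aromatic ring with 2 hetero atoms) in place of a group of 7 heavy atoms (2 carbon, 2 nitrogen, 2 oxygen, 1 sulfur; one five-membered non-aromatic ring with 3 hetero atoms), on an aromatic carbon. Among the compounds with values here, the only step that bears on this change is the one from compound 1 to compound 2, which swapped one five-membered non-aromatic ring on the same aromatic carbon for another and moved the number by a modest amount. The group entering in compound 3 is again a five-membered non-aromatic ring with 2 hetero atoms, as in compound 1, so a step back toward the number of compound 1 is the simplest reading, though the size of such a step cannot be fixed from one precedent.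

For compound 3 the expected number in this assay is 600 nM, with a range of 250 nM to 1500 nM, which corresponds to an estimated step of a 1.9-fold higher number from compound 2 to compound 3 (0.29 log units; within the scatter).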

Compound 3, half-maximal inhibitory concentration: 1950 nM
Compound 3: middle estimate off by 3.3-fold (0.51 log units), on the low side; the measured number lies above the stated range.
By their numbers in this assay, from the lowest: compound 2; then compound 1; then compound 3.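

In this assay, the aromatic carbon of the five-membered aromatic ring with 2 nitrogen proves more sensitive to the identity of the attached non-aromatic ring than the first step showed: a 6.3-fold higher number from compound 2 to compound 3 (0.80 log units; beyond the scatter) is a larger change than a 2.6-fold lower number from compound 1 to compound 2 (0.41 log units; beyond the scatter). The two rings with a carbonyl also do not behave alike, since 2-oxo-1,3-oxazolidin-3-yl in place of 3-methyl-2-oxoimidazolidin-1-yl gives a 2.5-fold higher number from compound 1 to compound 3 (0.39 log units; beyond the scatter), which places compound 3 at the weak end of this set of three, with all three steps beyond the scatter. The group leaving compound 2 has 1 hydrogen-bond donor and the group entering compound 3 has 0, but no measurement at hand accounts for any of these differences.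

The compounds shown leave open how much of the gap between compound 1 and compound 3 belongs to the ring oxygen and how much to the methyl, a question that 2-oxoimidazolidin-1-yl without the methyl would address. From the compounds shown here alone, it also remains open whether a six-membered ring such as morpholine or an open-chain group such as acetamido would hold the number of compound 2 or lose it.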